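Adding a Hydroxy Group to Two Inactive Scaffolds

A few compounds are considered here, and "the series" means these few. Any claim that something is new, unique, unknown or untested is made for them only; others in the source may bear on it.

Three compounds have been measured in a functional assay on KB403 cells (Homo sapiens) for cytotoxicity, read by MTT assay, with stated times of 6 h and 48 h; a higher number here means a weaker inhibitor, a lower number a stronger inhibitor:

Compound 1 `O=C(/C=C/c1cc(Br)c(Br)[nH]1)c1ccccc1O` gives >= 100000 nM, which is a limit of the assay and not a number.
Compound 2 `O=C(/C=C/c1cc(Br)c(Br)[nH]1)c1ccccc1` gives >= 100000 nM, likewise a limit of the assay.
Compound 3 `Cn1c(-c2cc(-c3ccccc3)no2)cc(Br)c1Br` gives >= 100000 nM, again a limit of the assay.

All three values sit at the same point: the limit of >= 100000 nM in this assay, at which 3 of the 3 values shown sit. Compound 1 and compound 2 share one core and differ in a single place, namely (hydroxy in place of hydrogen on an aromatic carbon). The step this change made, a step that the two limits leave unreadable from compound 2 to compound 1, cannot be read, since both ends are limits rather than numbers. Compound 3 has a different core, and how its core differs from that of compound 2 is not broken down here.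

Compound 4 `Cn1c(-c2cc(-c3ccccc3O)no2)cc(Br)c1Br` has not yet been measured in this assay. It is made from compound 3 by hydroxy in place of hydrogen on an aromatic carbon. The place is described in the same words for both pairs, so this is the same change seen between compound 2 and compound 1, now carried out on the other core. Because a step that the two limits leave unreadable from compound 2 to compound 1 gave no readable step, there is no sign that this change moves the read-out. Because compound 3 sits at >= 100000 nM in this assay, compound 4 is expected to stay at the limit as well. The step from this change, a number no higher from compound 3 to compound 4 (the limit leaves the size open), is expected to be negligible. Compound 4 is estimated at 100000 nM, with a likely range from 30000 nM to 300000 nM, and the assay will most probably report only a limit.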

Compound 4, half-maximal inhibitory concentration: 2450 nM
Estimate against measurement, compound 4: 41-fold (1.61 log units) above; measured number below the stated range.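

In this assay, adding the hydroxy group to the core of compound 3 gives an at least 40-fold lower number from compound 3 to compound 4 (1.61 log units; beyond the scatter), so on this core a single change turns a compound sitting at a limit into one with a measured number. The same change on the other core cannot be read, as compound 1 and compound 2 both sit at a limit and not at a number, which leaves no size to set beside the new step, and the wider picture remains dominated by such limits: the limit of >= 100000 nM in this assay, at which 3 of the 4 values shown sit. This shows that the effect of the change does not simply carry over in a visible way from one core to the other, since only compound 4 gains a number, but it does not show why the two cores differ, or how far compound 1 and compound 2 lie from each other.

The compounds shown carry only hydrogen or hydroxy at this place on the six-membered ring, so it remains open whether a methoxy group, an amine or a carboxylic acid there would also give a measured number. Going by these compounds, it also remains open whether the hydroxy group would do the same at another place on that ring, or on any core beyond these two.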